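The source may hold more compounds than are shown below. What is called first, only, known or untested is meant among the compounds shown, and "the series" means these compounds.

Measured in an assay on isolated protein for inhibition of cathepsin S (Homo sapiens); on this read-out lower numbers stand for stronger inhibition and higher numbers for weaker inhibition:
compound 1 `N#CC1(NC(=O)[C@@H](CC(=O)N2CCOCC2)CC2CCCCC2)CC1` gives 135 nM
compound 2 `N#C[C@@]1(NC(=O)[C@@H](CC(=O)N2CCOCC2)CC2CCCCC2)CCN(C2CCCC2)C1` gives 75 nM
compound 3 `N#C[C@@]1(NC(=O)[C@@H](CC(=O)N2CCOCC2)CC2CCCCC2)CCN(C2CCCCCC2)C1` gives 23 nM

Compound 3 holds the lowest number of the three, and the values of compound 1 and compound 3 sit well apart. For the measured compounds named here, the one step that matters here is a 3.3-fold lower number from compound 2 to compound 3 (0.51 log units; beyond the scatter), where a larger ring on the ring nitrogen went with the lower number. Compound 4 `CC(C)N1CC[C@@](C#N)(NC(=O)[C@@H](CC(=O)N2CCOCC2)CC2CCCCC2)C1` goes the other way: isopropyl in place of cycloheptyl on an amine nitrogen in a ring, a smaller group than either ring. On that basis the number is expected to rise beyond the scatter, roughly back toward what compound 2 shows, so the estimate for compound 4 in this assay is 100 nM (range 40 nM to 250 nM), a step of a 4.3-fold higher number from compound 3 to compound 4 (0.64 log units; beyond the scatter).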

Compound 4, half-maximal inhibitory concentration: 66 nM
Compound 4: middle estimate off by 1.5-fold (0.18 log units), on the high side; the measured number falls inside the stated range.
By their numbers in this assay, from the lowest: compound 3; then compounds 4, 2 and 1 (each within the scatter of the next, the first and the last beyond it).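

In this assay, the number on the ring nitrogen does not simply follow the size of the group: replacing cycloheptyl with isopropyl gives a 2.9-fold higher number from compound 3 to compound 4 (0.46 log units; beyond the scatter), but the comparison with cyclopentyl gives a 1.1-fold lower number from compound 2 to compound 4 (0.06 log units; within the scatter), so isopropyl and cyclopentyl cannot be told apart here. Of these three groups, only cycloheptyl stands apart. Even with isopropyl, replacing 1-cyanocyclopropyl with 3-cyano-1-isopropylpyrrolidin-3-yl on the amide-type nitrogen gives a 2.0-fold lower number from compound 1 to compound 4 (0.31 log units; beyond the scatter).

As far as these compounds go, whether a cyclohexyl or tetrahydropyranyl ring on this nitrogen would match cycloheptyl remains open. Nothing shown explains these differences.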